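Seven-substituted nucleoside series: iodo to ethynyl on compound 3

A few compounds are considered here, and "the series" means these few. Any claim that something is new, unique, unknown or untested is made for them only; others in the source may bear on it.

Three measured compounds share one nucleoside core. Compound 1 `O=c1[nH]cnc2c1c(-c1ccoc1)cn2[C@@H]1O[C@H](CO)[C@@H](O)[C@H]1O` gives 6370 nM in a functional assay on HL-60 cells (Homo sapiens) for antiproliferative activity, read by XTT assay, with a stated time of 72 h; a lower number here means a stronger inhibitor, a higher number a weaker inhibitor. Compound 2 `CN(C)c1ncnc2c1c(-c1ccsc1)cn2[C@@H]1O[C@H](CO)[C@@H](O)[C@H]1O` gives 1920 nM, and compound 3 `Cc1ncnc2c1c(I)cn2[C@@H]1O[C@H](CO)[C@@H](O)[C@H]1O` gives 2650 nM. Compound 3 stands second highest of the three numbers; its gap to compound 2 lies within the scatter, while compound 1 sits beyond the scatter on the weaker side.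

Compound 4 `C#Cc1cn([C@@H]2O[C@H](CO)[C@@H](O)[C@H]2O)c2ncnc(C)c12` is the unmeasured analogue. The change from compound 3 is ethynyl in place of iodo on an aromatic carbon. Among the measured compounds shown here, no measured pair shows this change, so its size rests on no direct precedent. A moderate step toward a lower number is expected, and compound 4 is estimated at 900 nM, between 200 nM and 4000 nM, meaning an expected step of a 2.9-fold lower number from compound 3 to compound 4 (0.47 log units; beyond the scatter).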

Compound 4, half-maximal inhibitory concentration: 1110 nM
Compound 4: the middle estimate sits 1.2-fold (0.09 log units) below what was measured; measured number inside the range.
By their numbers in this assay, from the lowest: compounds 4, 2 and 3 (each within the scatter of the next, the first and the last beyond it); then compound 1.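

In this assay, among the compounds shown here, ethynyl in place of iodo on an aromatic carbon gives a 2.4-fold lower number from compound 3 to compound 4 (0.38 log units; beyond the scatter) as the first step read across a single place. This aromatic carbon therefore accepts a group with a triple bond outside aromatic rings, and the number moves down, not up. No measurement at hand accounts for this step.

Open, on these data alone, is whether a nitrile or a longer chain such as propynyl on the same carbon moves the number further. Also open, as far as these compounds go, is whether ethynyl gives a similar step on the cores of compound 1 and compound 2.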